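Notes on compound 4 ahead of its measurement

The source may hold more compounds than are shown below. What is called first, only, known or untested is meant among the compounds shown, and "the series" means these compounds.

Three members of the shared core have been run in an assay on HL-60 cells for agonist activity at N-formyl peptide receptor 3 (Homo sapiens), read by calcium flux; on this read-out higher numbers stand for an effect only at larger amounts of compound and lower numbers for an effect already at smaller amounts. Compound 1, `CCc1cc(Cc2cccc(OC)c2)c(=O)n(CC(=O)Nc2ccc(I)cc2)n1`, gives > 50000 nM, which is a limit of the assay and not a number. Compound 2, `COc1ccc(Cc2cc(-c3ccc(Cl)cc3)nn(CC(=O)Nc3ccc(Br)cc3)c2=O)cc1`, gives > 50000 nM, again a limit. Compound 3, `Cc1cc(Cc2cccc(Cl)c2)c(=O)n(CC(=O)Nc2ccc(Br)cc2)n1`, gives > 50000 nM, also a limit. Among the measured compounds shown here, this is where compound 3 stands: the limit of > 50000 nM in this assay, at which 3 of the 3 values shown sit, so no number sets compound 3 apart from compound 1 or compound 2, and no measured pair of compounds differs in a single place, so nothing measured yet shows how a single change moves the read-out.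

Compound 4, `Cc1cc(Cc2ccc(C#N)cc2)c(=O)n(CC(=O)Nc2ccc(Br)cc2)n1`, is the next to be measured. It differs from compound 3 in one place: 4-cyanophenyl in place of 3-chlorophenyl on a saturated chain carbon bound to an aromatic carbon.

With compound 3 at the limit of this assay, the change is expected to leave compound 4 near that limit as well; the step of a number no higher from compound 3 to compound 4 (the limit leaves the size open) is expected to be none beyond the scatter. For compound 4 the estimate is 50000 nM, with a range from 10000 nM to 200000 nM, and the most likely outcome is that this assay again reports only a limit rather than a number.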

Compound 4, half-maximal effective concentration: > 50000 nM
Compound 4 ended at the assay's limit; the forecaster's own chance of this, stated with the estimate: 85%; the middle value sits exactly at the limit.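

In this assay compound 4 gives > 50000 nM as a limit of the assay and not a number. Among the compounds shown here, compound 3 also stands at a limit, so no step between compound 3 and compound 4 can be read. The compounds shown leave open how any single change on the shared core moves the read-out, since none of them yet gives a number: the limit of > 50000 nM in this assay, at which 4 of the 4 values shown sit.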